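A few compounds are considered here, and "the series" means these few. Any claim that something is new, unique, unknown or untested is made for them only; others in the source may bear on it.

In a functional assay on HCT-116 cells (Homo sapiens) for cytotoxicity (a higher number here means a weaker inhibitor, a lower number a stronger inhibitor), compound 2, `CCCCCCCCCC[C@@H]1CC(=O)N[C@H](CC(C)C)C(=O)N[C@@H](CO)C(=O)N[C@@H]([C@@H](C)O)C(=O)N[C@H](CC(C)C)C(=O)N[C@@H]([C@@H](C)CC)C(=O)O1`, gives 32000 nM. Among the compounds with values here, the only other measured compound, compound 1, `CCCCCCCCC[C@@H]1CC(=O)N[C@H](CC(C)C)C(=O)N[C@@H](CO)C(=O)N[C@@H]([C@@H](C)O)C(=O)N[C@H](CC(C)C)C(=O)N[C@@H]([C@@H](C)CC)C(=O)O1`, gives 22000 nM. Within the data shown here, these two values lie within the scatter of each other, so compound 2 does not stand apart from its one neighbour.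

Compound 3, `CC[C@H](C)[C@@H]1NC(=O)[C@@H](CC(C)C)NC(=O)[C@H]([C@@H](C)O)NC(=O)[C@H](CO)NC(=O)[C@@H](CC(C)C)NC(=O)C[C@@H](CCCCCCCCC(C)C)OC1=O`, has not yet been measured. It differs from compound 2 in a single place: methyl in place of hydrogen on a saturated chain carbon bound to two saturated chain carbons. This is methyl in place of hydrogen on a saturated chain carbon bound to two saturated chain carbons, so the end of the chain changes from ethyl to isopropyl.

Among the measured compounds shown here, one measured step bears on this change, since it is also methyl in place of hydrogen on a saturated chain carbon: a 1.5-fold higher number from compound 1 to compound 2 (0.16 log units; within the scatter). That step lengthens the chain, whereas this one branches it, so it is only a rough guide, and a single step is thin evidence. Even so, no step beyond the scatter is expected in this assay, and the estimated change is a 1.1-fold lower number from compound 2 to compound 3 (0.03 log units; within the scatter). Compound 3 is expected at 30000 nM, with an estimated range of 14000 nM to 65000 nM.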

Compound 3, half-maximal inhibitory concentration: 17000 nM
Estimate against measurement, compound 3: 1.8-fold (0.25 log units) above; low and high end bracket the measured number.
By their numbers in this assay, from the lowest: compounds 3, 1 and 2 (each within the scatter of the next).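

In this assay, turning the ethyl end of the chain into isopropyl gives a 1.9-fold lower number from compound 2 to compound 3 (0.27 log units; within the scatter) and so shows that a branch at this chain end, like the added length seen earlier, produces no step beyond the scatter. Read against the shorter unbranched chain, isopropyl in place of methyl gives a 1.3-fold lower number from compound 1 to compound 3 (0.11 log units; within the scatter) and shows that lengthening and branching together also stay within the scatter, so across these three compounds, changing only saturated carbons at the chain end gives no clear difference in the numbers. Nothing here explains why these numbers sit so close together, and no independent measurement bears on the matter.

The compounds shown cover only small changes made of saturated carbons, so they leave open whether a much shorter chain, a much longer chain or a phenyl ring at the chain end would give a step beyond the scatter. They also leave open what an amine, a hydroxyl or a carboxylic acid at the end of the chain would do to the number in this assay.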